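The source may report more compounds than this note shows. Statements on the series, on what has been measured and on what is new or still open speak of the compounds shown alone.

Compound 1 `O=C(CSc1nc(Nc2ccccc2)c2ccccc2n1)Nc1ccc(F)cc1` and compound 2 `O=C(CSc1nc(Nc2ccccc2)c2ccccc2n1)Nc1ccc(Cl)cc1` share one core, while compound 3 `C=CC(=O)Nc1cccc(NC(=O)CSc2nc(Nc3cccc(F)c3)c3ccccc3n2)c1` and compound 4 `C=CC(=O)Nc1cccc(NC(=O)CSc2nc(Nc3cccc(Cl)c3)c3ccccc3n2)c1` share another; the difference between the two cores is not broken down here. In a functional assay on MGC-803 cells (Homo sapiens) for inhibition, read by MTT assay, with a stated time of 72 h (on this read-out lower numbers stand for stronger inhibition and higher numbers for weaker inhibition), compound 1 reaches only a limit of > 50000 nM. Compound 2 gives 40400 nM in this assay. The step of an at least 1.2-fold lower number from compound 1 to compound 2 (0.09 log units; that floor lies within the scatter) is chloro in place of fluoro on an aromatic carbon. Its size is open at one end because compound 1 sits at the limit of > 50000 nM in this assay, at which 1 of the 3 values shown sits. Compound 3 gives 6250 nM in this assay, the lowest of the two numbers. Compound 4 carries the same kind of change, (chloro in place of fluoro on an aromatic carbon), though here the halogen sits meta to a large group rather than para to it. Compound 4 is expected to give about 5000 nM in this assay, between 2500 nM and 10000 nM, an expected step of a 1.3-fold lower number from compound 3 to compound 4 (0.10 log units; within the scatter) that rests on compound 2 standing at 40400 nM after the like change.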

Compound 4, half-maximal inhibitory concentration: 7830 nM
Estimate against measurement, compound 4: 1.6-fold (0.19 log units) below, and the stated range covers the measured number.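

In this assay, chloro in place of fluoro on the core of compound 3 gives a 1.3-fold higher number from compound 3 to compound 4 (0.10 log units; within the scatter), so on this core the change leaves the two compounds within the usual scatter of each other. Set beside the step on the other core, this gives no sign that the change behaves differently from one core to the other, but it does not show that it behaves alike: the same change on two cores in this assay, an at least 1.2-fold lower number (0.09 log units; that floor lies within the scatter) from compound 1 to compound 2 and a 1.3-fold higher number (0.10 log units; within the scatter) from compound 3 to compound 4; the limit leaves it open whether they differ. Compound 1 gives only a limit, not a number: the limit of > 50000 nM in this assay, at which 1 of the 4 values shown sits.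

The compounds shown leave open how either core would respond to a bromo group, an amine or a carboxylic acid at the same place. They also leave open whether such a group would move the read-out beyond the scatter.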